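The source may report more compounds than this note shows. Statements on the series, on what has been measured and on what is new or still open speak of the compounds shown alone.

Measured so far:
compound 1 `c1ccc(CNc2[nH]ccc3ncnc2-3)cc1`, in a functional assay on the whole organism (Pleural cavity) with Rattus norvegicus as the target (a lower number here means that less compound is needed, a higher number that more compound is needed for the effect), compound 1 gives 9 mg/kg;
compound 2 `Sc1[nH]ccc2ncnc1-2`, in this assay compound 2 gives 8 mg/kg;
compound 3 `CN(C)c1[nH]ccc2ncnc1-2`, in this assay compound 3 gives 9 mg/kg.

Compound 3 stands level with compound 1 at the digits shown, the two of them together the highest of the three numbers; its furthest neighbour is compound 2, and even that gap lies within the scatter. Compound 4 `CSc1[nH]ccc2ncnc1-2` differs from compound 3 by methylsulfanyl in place of dimethylamino on an aromatic carbon. For the measured compounds named here, the one measured step that bears on this exchange at the same place is a 1.1-fold higher number from compound 2 to compound 3 (0.05 log units; within the scatter), a sulfur-for-nitrogen swap that moved nothing beyond the scatter. Compound 4 is therefore expected to show no step beyond the scatter, a 1.1-fold lower number from compound 3 to compound 4 (0.02 log units; within the scatter). The estimate for compound 4 is 8.5 mg/kg, within 4 mg/kg to 18 mg/kg.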

Compound 4, dose for half-maximal effect: 9 mg/kg
Estimate against measurement, compound 4: 1.1-fold (0.02 log units) below; low and high end bracket the measured number.
By their numbers in this assay, from the lowest: compounds 2, 1, 3 and 4 (each within the scatter of the next).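

Methylsulfanyl in place of dimethylamino on this aromatic carbon, next to the ring nitrogen, gives no change at the digits printed from compound 3 to compound 4 (within the scatter) in this assay and so leaves the number where it was. Methyl in place of hydrogen on the sulfur gives a 1.1-fold higher number from compound 2 to compound 4 (0.05 log units; within the scatter) in the same assay, so sulfanyl, methylsulfanyl and dimethylamino all lie within the scatter of one another at this position. Nothing available explains why these groups read alike.

From the compounds shown here alone, whether a carboxylic acid, a hydroxyl or a longer alkyl chain on this carbon would move the number beyond the scatter remains open.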